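Urea Series on Raji Cells: Toward Compound 4

The compounds below may be only part of what the source reports. "The series", "measured", "known", "first", "only" and "open" are said of these compounds alone.

Compound 1, `Cc1cc(NC(=O)Nc2ccc(C)c(Cl)c2)c2ccccc2n1`: in an ADME assay on Raji cells (Homo sapiens) for cytotoxicity, with a stated time of 72 h (a higher number here means that more compound is needed for the effect, a lower number that less compound is needed), compound 1 gives > 25000 nM, which is a limit of the assay.
Compound 2, `Cc1cc(NC(=O)Nc2cccc(Cl)c2)c2ccccc2n1`: in this assay compound 2 gives 18000 nM.
Compound 3, `Cc1cc(NC(=O)Nc2cccc(C(N)=O)c2)c2ccccc2n1`: in this assay compound 3 gives > 25000 nM, which is a limit of the assay.

Compound 2 holds the only numerical result in this assay; the other two results are limits, as the limit of > 25000 nM in this assay, at which 2 of the 3 values shown sit, records. The step of an at least 1.3-fold lower number from compound 1 to compound 2 (0.14 log units; that floor lies within the scatter) arises from hydrogen in place of methyl on an aromatic carbon, and the step of an at least 1.3-fold higher number from compound 2 to compound 3 (0.14 log units; that floor lies within the scatter) from carbamoyl in place of chloro on an aromatic carbon. Both are floors that lie within the scatter, so neither shows a real movement of the number.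

Compound 4, `Cc1cc(NC(=O)Nc2ccccc2N)c2ccccc2n1`, differs from compound 2 by 2-aminophenyl in place of 3-chlorophenyl on an amide-type nitrogen. Both measured steps altered the substitution on the ring that this change replaces outright, and neither shifted the result beyond the scatter, so the step expected for compound 4 is a 1.4-fold higher number from compound 2 to compound 4 (0.14 log units; within the scatter), with no clear direction. Compound 4 is therefore expected to give about 25000 nM in this assay, with a range from 12000 nM to 60000 nM, and it is expected that the assay may again report only a limit.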

Compound 4, half-maximal effective concentration: > 25000 nM
Compound 4: only a limit was reported; the forecaster's own chance of this, stated with the estimate: 55%; the middle value lies on the limit itself.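

In this assay, among these compounds, 2-aminophenyl in place of 3-chlorophenyl on an amide-type nitrogen gives an at least 1.3-fold higher number from compound 2 to compound 4 (0.14 log units; that floor lies within the scatter), so even exchanging the whole group at this place, and not only one substituent on its ring, shows no real movement of the number. The group that enters has 1 hydrogen-bond donor and 1 hydrogen-bond acceptor where the group that leaves has 0 of each, yet the step is only a floor within the scatter. Compound 2 remains the only compound with a numerical result, and the new result adds to the values at the assay's limit: the limit of > 25000 nM in this assay, at which 3 of the 4 values shown sit.

Compound 1, compound 3 and compound 4 all carry the same limit, so the results shown cannot place them in any order. From the compounds shown here alone, it remains open whether an amine elsewhere on this ring, a carboxylic acid on it, or a longer chain in place of the ring on the amide-type nitrogen would give a numerical result, and how much of this change belongs to the amine and how much to the loss of the chlorine.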